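The compounds below may be only part of what the source reports. "The series", "measured", "known", "first", "only" and "open" are said of these compounds alone.

Measured compounds in an assay on isolated protein for inhibition of vitamin D3 receptor (Homo sapiens), read by fluorescence polarization; on this read-out higher numbers stand for weaker inhibition and lower numbers for stronger inhibition:

Compound 1 `CC(C)N(C(=O)CCNC(=O)c1ccc(S(C)(=O)=O)c([N+](=O)[O-])c1)C(C)C`; in this assay compound 1 gives > 60000 nM, which is a limit of the assay rather than a number.
Compound 2 `CC(C)N(C(=O)C1CCN(C(=O)c2ccc(S(C)(=O)=O)c([N+](=O)[O-])c2)CC1)C(C)C`; in this assay compound 2 gives > 60000 nM, again a limit.
Compound 3 `CS(=O)(=O)c1ccc(C(=O)NCCC(=O)N2CCc3ccccc3C2)cc1[N+](=O)[O-]`; in this assay compound 3 gives > 60000 nM, also a limit.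

Compound 4 `CS(=O)(=O)c1ccc(C(=O)N2CCC(C(=O)N3CCc4ccccc4C3)CC2)cc1[N+](=O)[O-]` has not yet been measured. The difference between the core of compound 1 and the core of compound 2 is not broken down here. Compound 3 arises from compound 1 by the change (1,2,3,4-tetrahydroisoquinolin-2-yl in place of diisopropylamino on a carbonyl carbon), and the step that the two limits leave unreadable from compound 1 to compound 3 cannot be read, because of the limit of > 60000 nM in this assay, at which 3 of the 3 values shown sit. Compound 4 arises from compound 2 by the change (1,2,3,4-tetrahydroisoquinolin-2-yl in place of diisopropylamino on a carbonyl carbon); the surroundings differ, a saturated chain carbon in the first case and a saturated ring carbon in the second, so this is the same kind of change, not the same one. With every value shown sitting at the limit, the step from compound 2 to compound 4 is estimated as a step that the limit leaves unreadable from compound 2 to compound 4, and compound 4 is expected to give about 100000 nM, most likely reported only as a limit again.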

Compound 4, half-maximal inhibitory concentration: > 60000 nM
Compound 4: no number, only a limit (the forecaster's own chance of this, stated with the estimate: 85%); the middle value lies beyond the limit too.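

In this assay, no step can be read from compound 2 to compound 4, because neither compound gives a number: the limit of > 60000 nM in this assay, at which 4 of the 4 values shown sit.

The compounds shown leave open whether 1,2,3,4-tetrahydroisoquinolin-2-yl in place of diisopropylamino changes inhibition at all, and what kind of structure would give a measurable value in this assay.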